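Methoxy on the Benzyl Group: Compound 1 to Compound 3

The source may report more compounds than this note shows. Statements on the series, on what has been measured and on what is new or still open speak of the compounds shown alone.

Measured so far:
- Compound 1, `CC(C)(Oc1ccc(-c2cc(=O)c3ccccc3o2)cc1)C(=O)NC1CCN(Cc2ccccc2)CC1`; in a functional assay on HepG2 cells (Homo sapiens) for cytotoxicity, read by MTT assay, with a stated time of 72 h (a higher number here means a weaker inhibitor, a lower number a stronger inhibitor), compound 1 gives > 20000 nM.
- Compound 2, `O=C(COc1ccc2c(=O)cc(-c3ccccc3)oc2c1)NC1CCN(Cc2ccccc2)CC1`; in this assay compound 2 gives 16700 nM.

Compound 1 stands in this assay only as a limit of the assay, not as a number. Where it sits is described by the limit of > 20000 nM in this assay, at which 1 of the 2 values shown sits. For the measured compounds named here, compound 2 is the only compound with an actual number here, and no step between it and compound 1 is counted, so the two values are simply set side by side: both show weak inhibition.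

Compound 3, `COc1ccc(CN2CCC(NC(=O)C(C)(C)Oc3ccc(-c4cc(=O)c5ccccc5o4)cc3)CC2)cc1`, is not yet measured. It differs from compound 1 in one place: methoxy in place of hydrogen on an aromatic carbon. Because compound 1 is described only by the limit of > 20000 nM in this assay, at which 1 of the 2 values shown sits, the size of any step from compound 1 to compound 3 cannot be read from a measured pair; the expectation is that this small change leaves the weak inhibition largely as it is, so a step within the scatter, or none, is expected, as in a step that the limit leaves unreadable from compound 1 to compound 3. For compound 3 the expected value in this assay is 25000 nM, with a range from 10000 nM to 60000 nM.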

Compound 3, half-maximal inhibitory concentration: 2800 nM
For compound 3 the middle estimate is 8.9-fold (0.95 log units) above the measured one; measured number outside the range, below it.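

Changing benzyl to 4-methoxybenzyl gives an at least 7.1-fold lower number from compound 1 to compound 3 (0.85 log units; beyond the scatter) in this assay, so this aromatic carbon, para to a large group, is a place where a small substituent can make a clear difference to the read-out. For the compounds shown here, the earlier compounds could not show this, since no step between compound 1 and compound 2 was counted; this is the first pair that differs in one place, and it separates the effect of the methoxy from everything else in the molecule. The value of compound 1 is a limit of the assay and not a number, so the step has a known minimum but no known full size: the limit of > 20000 nM in this assay, at which 1 of the 3 values shown sits.

What the compounds shown leave open is whether this stronger inhibition belongs to methoxy in particular or would also follow from another group on the same carbon, such as a hydroxyl, a fluorine or a longer chain like ethoxy. From the compounds shown here alone, it also remains open whether the same change on the benzyl group of compound 2, with its different core and linker, would produce a step of similar size.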